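The source may report more compounds than this note shows. Statements on the series, on what has been measured and on what is new or still open speak of the compounds shown alone.

Compound 3, with the structure `C=CCn1c(=O)/c(=C\c2cc(Br)ccc2F)[nH]c(=O)/c1=C\c1ccccc1OC`, gives 34600 nM in a functional assay on HeLa cells (Homo sapiens) for cytotoxicity, read by CCK-8 assay, with a stated time of 72 h; on this read-out lower numbers stand for stronger inhibition and higher numbers for weaker inhibition. Within the set that has been measured, this is the highest number of the two that were reported: compound 2, whose structure is `C=CCn1c(=O)/c(=C\c2cccc(F)c2)[nH]c(=O)/c1=C\c1ccccc1OC`, gives 9100 nM in this assay, and compound 1, with the structure `COc1ccccc1/C=c1/[nH]c(=O)/c(=C\c2ccccc2OC)n(C)c1=O`, is reported in this assay only as "not active" (no number reported) without a number. Among the compounds with values here, the one measured step, a 3.8-fold higher number from compound 2 to compound 3 (0.58 log units; beyond the scatter), shows that changing the substituents on the aryl ring on the double-bonded chain carbon bound to an aromatic carbon can move the number by a modest amount.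

Compound 4, with the structure `C=CCn1c(=O)/c(=C\c2ccc(F)c(Br)c2)[nH]c(=O)/c1=C\c1ccccc1OC`, differs from compound 3 by 3-bromo-4-fluorophenyl in place of 5-bromo-2-fluorophenyl on a double-bonded chain carbon bound to an aromatic carbon. Within the data shown here, no measured pair shows exactly this rearrangement, so the only guide is the size of the step from compound 2 to compound 3, which sets a scale for what a change on this ring can do. A step of similar or smaller size is expected, in either direction, with compound 4 likely staying near compound 3 or moving part-way back toward compound 2; this expectation corresponds to a 1.6-fold lower number from compound 3 to compound 4 (0.20 log units; within the scatter). Compound 4 is therefore estimated at 22000 nM in this assay, with a plausible range from 7000 nM to 70000 nM.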

Compound 4, half-maximal inhibitory concentration: "not active" (no number reported)
Compound 4: no number reported, so the estimate cannot be set against anything.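

Within the data shown here, compound 4 carries no number, so no step from compound 3 to compound 4 can be read. No measured evidence bears on this result. The compounds shown leave open how 3-bromo-4-fluorophenyl and 5-bromo-2-fluorophenyl truly compare in this assay at this place.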